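Dropping the para-chloro from a hydrazone chalcone analogue

The source may hold more compounds than are shown below. What is called first, only, known or untested is meant among the compounds shown, and "the series" means these compounds.

Compound 1 `COc1ccc(OC)c(/C=C/c2nnc(Nc3ccc(Cl)cc3)o2)c1`: > 100000 nM
Compound 2 `COc1ccc(OC)c(/C=C/C(=O)N/N=C/c2ccc(Cl)cc2)c1`: 62900 nM

In a functional assay on IGROV-1 cells (Homo sapiens) for antiproliferative activity, read by sulforhodamine B assay, with a stated time of 48 h (a lower number here means a stronger inhibitor of growth, a higher number a weaker inhibitor of growth), compound 1 gives only a limit, > 100000 nM. For the measured compounds named here, compound 2 gives the single numerical value here, 62900 nM, so it stands as the one compound with a measured number. The other result, that of compound 1, is a limit (the limit of > 100000 nM in this assay, at which 1 of the 2 values shown sits). Compound 3 `COc1ccc(OC)c(/C=C/C(=O)N/N=C/c2ccccc2)c1` differs from compound 2 by hydrogen in place of chloro on an aromatic carbon. Going by the values given here, no measured step of this kind is available, so the expected change is small, at most within the scatter, leaning toward weaker growth inhibition; the expected step is a 1.4-fold higher number from compound 2 to compound 3 (0.13 log units; within the scatter). Compound 3 is estimated at 85000 nM, between 30000 nM and 200000 nM.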

Compound 3, concentration for total growth inhibition: > 100000 nM
Compound 3: only a limit was reported; the forecaster's own chance of this, stated with the estimate: 35%; middle value at least 1.1-fold (0.07 log units) away from the limit.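

In this assay, for the compounds shown here, putting hydrogen in place of chloro on the aromatic carbon gives the first reading for this position: an at least 1.5-fold higher number from compound 2 to compound 3 (0.20 log units; that floor lies within the scatter). Compound 3 therefore joins the compounds that give only a limit: the limit of > 100000 nM in this assay, at which 2 of the 3 values shown sit. Going by these compounds alone, the step is a floor rather than a size, so it cannot show whether the chloro matters here, and compound 2 remains the only compound with a number.

The compounds shown leave open how far compound 3 truly lies from compound 2. They also leave open whether a fluoro, a methoxy or an amine at this place would give a measured number.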